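The source may report more compounds than this note shows. Statements on the series, on what has been measured and on what is new or still open speak of the compounds shown alone.

Measured so far:
- compound 1 `Cc1ccc(CN2C(=O)S/C(=C\c3ccc(N(C)C)cc3)C2=O)cc1` — 35.8% in a functional assay on the whole organism (plasma) with Mus musculus as the target, with a stated time of 15 days, at a dose of 20 mg/kg by the oral route; a lower number here means a weaker effect, a higher number a stronger effect of the compound at the dose given
- compound 2 `Cc1ccc(CN2C(=O)S/C(=C\c3ccccc3Cl)C2=O)cc1` — 47%

Compound 2 gives the higher of the two values, and its gap to compound 1 lies beyond the scatter. Compound 3 `Cc1ccc(CN2C(=O)S/C(=C\OCc3ccccc3)C2=O)cc1` has not yet been measured; it differs from compound 2 by benzyloxy in place of 2-chlorophenyl on a double-bonded chain carbon bound to a double-bonded ring carbon. Among the measured compounds shown here, no measured pair shows this kind of change, so the size of the step is open. The expected step is a number 15 percentage points lower from compound 2 to compound 3 (beyond the scatter), a modest fall. Compound 3 is therefore estimated at 32%, with a range from 12% to 52%.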

Compound 3, a percentage reported as activity, at one dose (the size of the read-out at that dose, not a potency): 27.7%
Beside the measured number, compound 3's estimate is 4.3 percentage points above it; measured number inside the range.
By their numbers in this assay, from the lowest: compounds 3 and 1 (each within the scatter of the next); then compound 2.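

In this assay, the exchange of 2-chlorophenyl for benzyloxy on a double-bonded chain carbon bound to a double-bonded ring carbon gives a number 19.3 percentage points lower from compound 2 to compound 3 (beyond the scatter), so this position does not tolerate every aromatic group equally. Benzyloxy brings one hydrogen-bond acceptor where 2-chlorophenyl has none, but this single pair cannot separate that difference from the others. No measured data here account for the fall.

Open, from the compounds shown here alone, is whether phenyl without chlorine would stay nearer compound 2. Also open, going by these compounds, is where phenoxy, an amine or a carboxylic acid at this place would fall.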